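Amino for Methoxy on a Nucleoside: Cytotoxicity Outlook

A few compounds are considered here, and "the series" means these few. Any claim that something is new, unique, unknown or untested is made for them only; others in the source may bear on it.

Compound 2 (`COc1nc(O)nc2c1ncn2[C@@H]1O[C@H](CO)[C@@H](O)[C@@]1(C)O`) is one of two nucleosides examined in an ADME assay on Vero cells (Chlorocebus sabaeus) for cytotoxicity, with a stated time of 3 days; a higher number here means that more compound is tolerated, a lower number that less compound is tolerated. Its result is a limit rather than a number: in this assay compound 2 gives > 100000 nM. The other compound, compound 1 (`C[C@@]1(O)[C@H](O)[C@@H](CO)O[C@H]1n1cnc2c(N)nc(N=[N+]=[N-])nc21`), likewise returns a limit, compound 1 giving > 100000 nM in this assay. For the measured compounds named here, compound 2 therefore sits at the upper boundary of what the measurement resolves, sharing that position with the only other compound measured, as summarised by the limit of > 100000 nM in this assay, at which 2 of the 2 values shown sit. Going by the values given here, no pair of compounds differing in a single place has been measured, so no step size is known from data.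

Compound 3 (`C[C@@]1(O)[C@H](O)[C@@H](CO)O[C@H]1n1cnc2c(N)nc(O)nc21`) differs from compound 2 by the change (amino in place of methoxy on an aromatic carbon), that is, amino in place of methoxy on an aromatic carbon. With both measured compounds at the limit, no direction can be read from them, and the step from compound 2 to compound 3 is expected to be none beyond the scatter, a number no higher from compound 2 to compound 3 (the limit leaves the size open). Compound 3 is accordingly expected to give about 100000 nM in this assay, within a range of 50000 nM to 300000 nM, most likely again reported only as a limit.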

Compound 3, half-maximal cytotoxic concentration: > 100000 nM
Compound 3: only a limit was reported; the forecaster's own chance of this, stated with the estimate: 85%; the middle value lies on the limit itself.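

For the compounds shown here, compound 3 returns only a limit in this assay, as do compound 1 and compound 2, so no step from either of them to compound 3 can be read. All three share one boundary: the limit of > 100000 nM in this assay, at which 3 of the 3 values shown sit.

The compounds shown leave open whether amino in place of methoxy, or hydroxy in place of azido, on an aromatic carbon alters the half-maximal cytotoxic concentration in this assay at all.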